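This account rests on a few compounds, and the source may have more. Where it says the series, first, only, none or still open, it means among the compounds named here.

Three compounds that differ only in the group on an oxygen on an aromatic ring have been measured in a functional assay on a cell-free system (plasma, Oryctolagus cuniculus) for inhibition, with stated times of 5 min, 1 min and 6 min; a higher number here means a weaker inhibitor, a lower number a stronger inhibitor. Compound 1 `CCOC(=O)c1c(C)nc(-c2cccc(C#N)c2)n1OC(C)C` gives 6740 nM, compound 2 `CCOC(=O)c1c(C)nc(-c2cccc(C#N)c2)n1OCCCO` gives 11400 nM, and compound 3 `CCOC(=O)c1c(C)nc(-c2cccc(C#N)c2)n1OCc1ccc(OC)cc1` gives 6830 nM. Compound 3 lies within the scatter of both others, so the three values cannot be ranked.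

The next step leads to compound 4 `CCOC(=O)c1c(C)nc(-c2cccc(C#N)c2)n1OCc1ccccc1C#N`. The change is 2-cyanophenyl in place of 4-methoxyphenyl on a saturated chain carbon bound to an oxygen on an aromatic ring.

All three measured steps bear on this change, since each alters the same group. Replacing isopropyl with 3-hydroxypropyl gave a 1.7-fold higher number from compound 1 to compound 2 (0.23 log units; within the scatter). Replacing isopropyl with 4-methoxybenzyl gave a 1.0-fold higher number from compound 1 to compound 3 (0.01 log units; within the scatter). Replacing the hydroxyl-bearing chain with the 4-methoxybenzyl group gave a 1.7-fold lower number from compound 2 to compound 3 (0.22 log units; within the scatter). Within the data shown here, none of these steps left the scatter, but no measured compound carries a 2-cyanophenyl group at this place, so the estimate remains an extrapolation. No step beyond the scatter is therefore expected in this assay, and no direction is favoured. The expected step is a 1.1-fold higher number from compound 3 to compound 4 (0.04 log units; within the scatter). For compound 4 the estimated value is 7500 nM, with an expected range from 3400 nM to 16000 nM.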

Compound 4, half-maximal inhibitory concentration: 9380 nM
Compound 4: middle estimate off by 1.3-fold (0.10 log units), on the low side; measured number inside the range.
By their numbers in this assay, from the lowest: compounds 1, 3, 4 and 2 (each within the scatter of the next).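

In this assay, 2-cyanophenyl in place of 4-methoxyphenyl gives a 1.4-fold higher number from compound 3 to compound 4 (0.14 log units; within the scatter), so a nitrile-bearing ring at this place leaves the number within the scatter of the methoxy-bearing one. Compared with the two open-chain groups, the result reads the same way: 2-cyanophenyl in place of 2-hydroxyethyl gives a 1.2-fold lower number from compound 2 to compound 4 (0.08 log units; within the scatter), and 2-cyanobenzyl in place of isopropyl gives a 1.4-fold higher number from compound 1 to compound 4 (0.14 log units; within the scatter). The earlier compounds had shown this only for isopropyl, 3-hydroxypropyl and 4-methoxybenzyl, and the series now holds four groups on the oxygen with no step beyond the scatter, although nothing available explains this result.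

As far as these compounds go, it remains open whether any group on this oxygen can move the number beyond the scatter, for example an amine, a carboxylic acid or a longer chain. Since all four compounds share the same core, they also leave open how much of the inhibition depends on the rest of the molecule, such as the ethyl ester.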